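The compounds below may be only part of what the source reports. "The series", "measured", "known", "first", "only" and "open" are said of these compounds alone.

In a functional assay on HeLa cells (Homo sapiens) for antiproliferative activity, read by MTT assay, with a stated time of 72 h (on this read-out lower numbers stand for stronger inhibition and higher numbers for weaker inhibition), compound 1 `CC(C)N1C(=O)COc2ccc(-c3cccc(NS(=O)(=O)c4ccc(F)cc4)c3)cc21` gives 22700 nM and compound 2 `O=C1COc2ccc(-c3cccc(NS(=O)(=O)c4ccc(F)cc4)c3)cc2N1c1ccc(Cl)cc1` gives 35000 nM. Compound 3 `O=C1COc2ccc(-c3cccc(NS(=O)(=O)c4ccc(F)cc4)c3)cc2N1C1CC1` is known only as a limit, > 40000 nM. Compound 4 `COc1ccc(N2C(=O)COc3ccc(-c4cccc(NS(=O)(=O)c5ccc(F)cc5)c4)cc32)cc1` differs from compound 3 by 4-methoxyphenyl in place of cyclopropyl on an amide-type nitrogen in a ring, with 4-methoxyphenyl in place of cyclopropyl on an amide-type nitrogen in a ring. The closest measured change, between 4-chlorophenyl and cyclopropyl at this nitrogen, is an at least 1.1-fold higher number from compound 2 to compound 3 (0.05 log units; that floor lies within the scatter). The other two changes at this nitrogen are a 1.5-fold higher number from compound 1 to compound 2 (0.19 log units; within the scatter) and an at least 1.7-fold higher number from compound 1 to compound 3 (0.24 log units; that floor lies within the scatter). None of these goes beyond the scatter, so no step beyond the scatter is expected in this assay. The expected change is an at least 1.3-fold lower number from compound 3 to compound 4 (0.12 log units; that floor lies within the scatter). Compound 4 is estimated at 30000 nM, with an expected range from 14000 nM to 60000 nM.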

Compound 4, half-maximal inhibitory concentration: 13200 nM
Beside the measured number, compound 4's estimate is 2.3-fold (0.36 log units) above it; measured number outside the range, below it.
By their numbers in this assay, from the lowest: compounds 4, 1 and 2 (each within the scatter of the next, the first and the last beyond it). At a limit, above all of these: compound 3.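

Going by these compounds alone, at this nitrogen in this assay, 4-methoxyphenyl gives the first steps beyond the scatter, one in place of cyclopropyl (an at least 3.0-fold lower number from compound 3 to compound 4 (0.48 log units; beyond the scatter)) and one as methoxy in place of chloro on an aromatic carbon (a 2.7-fold lower number from compound 2 to compound 4 (0.42 log units; beyond the scatter)). In place of isopropyl, the change stays within the scatter (a 1.7-fold lower number from compound 1 to compound 4 (0.24 log units; within the scatter)). Compound 3 is known only as a limit, so its step is a floor: the limit of > 40000 nM in this assay, at which 1 of the 4 values shown sits.

Open, from the compounds shown here alone, is whether an amine or a carboxylic acid in place of methoxy on that aromatic ring would shift the number. Also open, going by these compounds, is what a longer chain on the nitrogen would do.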